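Aryl swap on the benzyl arm of an adenosine receptor A2b series

The compounds below may be only part of what the source reports. "The series", "measured", "known", "first", "only" and "open" are said of these compounds alone.

Measured compounds:
compound 1, `CCCn1c(=O)c2nc(-c3cnn(Cc4cccc(C)c4)c3)[nH]c2n(CCC)c1=O`: 36 nM in an in vitro assay on HEK293 cells for displacement of a labelled ligand from adenosine receptor A2b (Homo sapiens); on this read-out lower numbers stand for stronger inhibition and higher numbers for weaker inhibition
compound 2, `CCCn1c(=O)c2nc(-c3cnn(Cc4ccccc4C(F)(F)F)c3)[nH]c2n(CCC)c1=O`: 37 nM in this assay

Compound 2 sits level with compound 1: the two numbers in this assay lie within the usual scatter of each other, as the step of a 1.0-fold higher number from compound 1 to compound 2 (0.01 log units; within the scatter) shows. That step exchanged the aryl group on the saturated chain carbon bound to an aromatic nitrogen and left the read-out flat.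

Compound 3, `CCCn1c(=O)c2nc(-c3cnn(Cc4cccc(F)c4F)c3)[nH]c2n(CCC)c1=O`, is not yet measured. It differs from compound 2 by 2,3-difluorophenyl in place of 2-(trifluoromethyl)phenyl on a saturated chain carbon bound to an aromatic nitrogen. Among the compounds with values here, the only measured step that bears on this change is the one from compound 1 to compound 2, which altered the same aryl group at the same place and gave no movement beyond the scatter. On that basis no step beyond the scatter is expected in this assay from compound 2 to compound 3, in either direction; the expected step is a 1.1-fold higher number from compound 2 to compound 3 (0.03 log units; within the scatter). Compound 3 is therefore estimated at 40 nM in this assay, with an expected range of 15 nM to 110 nM.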

Compound 3, inhibition constant: 240 nM
The estimate for compound 3 lay 6.0-fold (0.78 log units) below the measured number, outside the stated range (above it).
By their numbers in this assay, from the lowest: compounds 1 and 2 (each within the scatter of the next); then compound 3.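

The aryl group on the saturated chain carbon bound to an aromatic nitrogen is not a silent position in this assay: the flat step a 1.0-fold higher number from compound 1 to compound 2 (0.01 log units; within the scatter) gave no sign of sensitivity here, whereas 2,3-difluorophenyl gives a 6.5-fold higher number from compound 2 to compound 3 (0.81 log units; beyond the scatter) and a 6.7-fold higher number from compound 1 to compound 3 (0.82 log units; beyond the scatter). Both steps lie beyond the scatter and start from aryl groups that are level with each other, so among the three aryl groups shown, 2,3-difluorophenyl alone stands apart, and neither 3-methylphenyl nor 2-(trifluoromethyl)phenyl shares its weaker number. No measurement at hand accounts for this loss.

Three compounds cannot separate the contribution of the fluorines from that of the two-substituent pattern, and a plain phenyl ring or a phenyl ring carrying one fluorine would be needed to tell these apart. Also open, from the compounds shown here alone, is how this arm responds to an aryl group carrying an amine or a carboxylic acid, and whether the same aryl change behaves alike with a longer chain in place of the single carbon linking the aryl group to the aromatic nitrogen.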